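The source may report more compounds than this note shows. Statements on the series, on what has been measured and on what is new or still open speak of the compounds shown alone.

Compound 1 `CCN/C(SC)=C(/C#N)C(=O)Nc1ccc(OCC)cc1` was tested in a functional assay on PANC-1 cells (Homo sapiens) for cytotoxicity, read by resazurin assay, with a stated time of 48 h (a lower number here means a stronger inhibitor, a higher number a weaker inhibitor), where compound 1 gives 41600 nM. Compound 2 `C=CCN/C(SC)=C(/C#N)C(=O)Nc1ccc(OCC)cc1` carries one change relative to compound 1, described as vinyl in place of methyl on a saturated chain carbon bound to an amine nitrogen, and in this assay compound 2 gives 21800 nM. The step itself, a 1.9-fold lower number from compound 1 to compound 2 (0.28 log units; within the scatter), is small.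

Compound 3 `CCNc1[nH]nc2nnn(-c3ccc(OCC)cc3)c(=O)c12` is built on a different core; how the two cores differ is not broken down here. In this assay compound 3 gives 16100 nM, which sits close to the value of compound 2.

Compound 4 `C=CCNc1[nH]nc2nnn(-c3ccc(OCC)cc3)c(=O)c12` has not yet been measured. It differs from compound 3 as vinyl in place of methyl on a saturated chain carbon bound to a nitrogen on an aromatic ring. Among the measured compounds shown here, this is the same kind of change as the one from compound 1 to compound 2, though the surroundings are not identical: in the earlier pair the chain carbon is bound to an amine nitrogen, whereas here it is bound to a nitrogen on an aromatic ring.

For the measured compounds named here, the expected step, a 1.5-fold lower number from compound 3 to compound 4 (0.17 log units; within the scatter), rests on the one earlier example, a 1.9-fold lower number from compound 1 to compound 2 (0.28 log units; within the scatter), and is therefore held modest. Compound 4 is expected to give about 11000 nM, most likely between 5000 nM and 25000 nM.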

Compound 4, half-maximal inhibitory concentration: 13300 nM
Compound 4: middle estimate off by 1.2-fold (0.08 log units), on the low side; the range from low to high includes it.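

In this assay, replacing ethylamino with allylamino gives a 1.2-fold lower number from compound 3 to compound 4 (0.08 log units; within the scatter), a step too small to tell apart from repeat-measurement noise. Set side by side, the steps on the two cores agree as far as these measurements can tell: the same change on two cores in this assay, a 1.9-fold lower number (0.28 log units; within the scatter) from compound 1 to compound 2 and a 1.2-fold lower number (0.08 log units; within the scatter) from compound 3 to compound 4, 1.6-fold (0.20 log units) apart, within the scatter of two such steps. This shows that the change carries from one core to the other without a detectable difference in size, but it does not show a real gain from the allyl group on either core, and two pairs in a single assay cannot give a rule for the whole series.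

The compounds shown leave open whether any other group in this place, such as a longer chain like butyl, a cyclopropyl ring, or a chain ending in an amine or a carboxylic acid, would shift the number beyond the scatter. They also leave open whether replacing the ethoxy group, which all of these compounds share, would matter more than this change does.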